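This account rests on a few compounds, and the source may have more. Where it says the series, first, only, none or still open, it means among the compounds named here.

Working notes on the series. In a functional assay on SK-HEP1 cells (Homo sapiens) for antiproliferative activity, read by sulforhodamine B assay, with a stated time of 72 h (on this read-out lower numbers stand for stronger inhibition and higher numbers for weaker inhibition), compound 1 `CCOC(=O)c1cnc2ccc(-c3cnc(OC)c(NS(C)(=O)=O)c3)cn12` gives 170 nM and compound 2 `COc1ncc(-c2ccc3ncc(C(=O)NCc4ccncc4)n3c2)cc1NS(=O)(=O)c1ccc(F)cc1F` gives 980 nM; compound 2 thus stands at the higher of the two numbers, its gap to compound 1 lying beyond the scatter. Compound 3 `COc1ncc(-c2ccc3ncc(C(=O)N4CCC(O)CC4)n3c2)cc1NS(=O)(=O)c1ccc(F)cc1F` is not yet measured; it differs from compound 2 only by 4-hydroxypiperidin-1-yl in place of ((pyridin-4-yl)methyl)amino on a carbonyl carbon. Going by the values given here, no measured pair shows what such a change does here. The step from compound 2 to compound 3 is expected to be small, likely none beyond the scatter: a 1.1-fold lower number from compound 2 to compound 3 (0.04 log units; within the scatter). For compound 3 the expected value is 900 nM, within a range of 300 nM to 3000 nM.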

Compound 3, half-maximal inhibitory concentration: 790 nM
For compound 3 the middle estimate is 1.1-fold (0.06 log units) above the measured one, and the stated range covers the measured number.
By their numbers in this assay, from the lowest: compound 1; then compounds 3 and 2 (each within the scatter of the next).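

Going by these compounds alone, with 4-hydroxypiperidin-1-yl in place of ((pyridin-4-yl)methyl)amino on a carbonyl carbon, the series shows a 1.2-fold lower number from compound 2 to compound 3 (0.09 log units; within the scatter) in this assay and so gives the first measured pair at this position. A non-aromatic ring with a hydroxyl and an aromatic ring on a methylamino link sit here with no difference beyond the scatter. Nothing measured accounts for this result.

From the compounds shown here alone, whether the hydroxyl matters stays open, and a plain piperidin-1-yl would test that. Going by these compounds, a morpholin-4-yl or dimethylamino group on the same carbonyl carbon also remains open.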